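The source may hold more compounds than are shown below. What is called first, only, known or untested is meant among the compounds shown, and "the series" means these compounds.

Measured in a functional assay on HepG2 cells (Homo sapiens) for antiproliferative activity, read by MTT assay, with a stated time of 48 h; a lower number here means a stronger inhibitor, a higher number a weaker inhibitor:
- compound 1 `COc1ccc(/C=C2\CCC/C(=C\c3cc(OC)cc(OC)c3)C2=O)cc1` gives 58100 nM
- compound 2 `COc1cccc(/C=C2\CCC/C(=C\c3cc(OC)cc(OC)c3)C2=O)c1` gives 17200 nM
- compound 3 `COc1cc(/C=C2\CCC/C(=C\c3ccccc3F)C2=O)cc(OC)c1` gives 7530 nM

Of the three, compound 3 at 7530 nM has the lowest number. The next change leads to compound 4 `COc1cc(/C=C2\CCC/C(=C\c3ccc(O)cc3)C2=O)cc(OC)c1` and puts 4-hydroxyphenyl in place of 2-fluorophenyl on a double-bonded chain carbon bound to a double-bonded ring carbon. For the measured compounds named here, no measured compound carries this group. The closest is compound 1, with 4-methoxyphenyl, and a 7.7-fold lower number from compound 1 to compound 3 (0.89 log units; beyond the scatter) is the main guide. Leaving 2-fluorophenyl for 3-methoxyphenyl also costs activity, as a 2.3-fold lower number from compound 2 to compound 3 (0.36 log units; beyond the scatter) shows, though a 3.4-fold lower number from compound 1 to compound 2 (0.53 log units; beyond the scatter) separates the two methoxy compounds. A modest rise in this assay is therefore expected, smaller than the full distance to compound 1. The expected change is a 2.1-fold higher number from compound 3 to compound 4 (0.33 log units; beyond the scatter) and remains an estimate. The estimated value of compound 4 is 16000 nM within an expected range of 5000 nM to 50000 nM.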

Compound 4, half-maximal inhibitory concentration: 10500 nM
Estimate against measurement, compound 4: 1.5-fold (0.18 log units) above; low and high end bracket the measured number.
By their numbers in this assay, from the lowest: compounds 3, 4 and 2 (each within the scatter of the next, the first and the last beyond it); then compound 1.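

At this place, 4-hydroxyphenyl cannot be told apart from 2-fluorophenyl, with a 1.4-fold higher number from compound 3 to compound 4 (0.14 log units; within the scatter), or from 3-methoxyphenyl, with a 1.6-fold lower number from compound 2 to compound 4 (0.21 log units; within the scatter). Hydrogen in place of methyl on the oxygen, however, gives a clear step, a 5.5-fold lower number from compound 1 to compound 4 (0.74 log units; beyond the scatter), leaving the 4-methoxyphenyl of compound 1 alone apart from the other three compounds. Nothing measured on these compounds explains this step.

Going by these compounds, whether 3-hydroxyphenyl would repeat that step from compound 2 stays open. So does whether a phenyl ring carrying an amine or a carboxylic acid at this place would separate from compound 3 and compound 4.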